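The compounds below may be only part of what the source reports. "The series", "measured", "known", "first", "only" and "open" are said of these compounds alone.

Measured so far:
- compound 1, `CCc1ccc(C(=O)CCCN2CCC(C(O)(c3ccccc3)c3ccccc3)CC2)cc1`, gives 600 nM in an in vitro assay on Sf9 cells for inhibition of cytochrome P450 2J2 (Homo sapiens); on this read-out lower numbers stand for stronger inhibition and higher numbers for weaker inhibition
- compound 2, `O=C(CCCN1CCC(C(O)(c2ccccc2)c2ccccc2)CC1)c1ccc(CC(F)F)cc1`, gives 2200 nM in this assay

Within the data shown here, compound 2 stands at the higher of the two numbers measured; its only neighbour, compound 1, sits at the lower one, and the step of a 3.7-fold higher number from compound 1 to compound 2 (0.56 log units; beyond the scatter) separates them. Compound 3, `O=C(CCCN1CCC(C(O)(c2ccccc2)c2ccccc2)CC1)c1ccc(CCCO)cc1`, is not yet measured. It differs from compound 2 by 2-hydroxyethyl in place of difluoromethyl on a saturated chain carbon bound to an aromatic carbon. Among the measured compounds shown here, the one measured step touches the same saturated chain carbon bound to an aromatic carbon, where the step of a 3.7-fold higher number from compound 1 to compound 2 (0.56 log units; beyond the scatter) was modest and beyond the scatter. For the measured compounds named here, no measured compound carries a hydroxyl on that chain, so the direction of the present change is not anchored by any step; the step from compound 1 to compound 2 shows only that this position responds to change. For compound 3 the expectation is therefore a number not far from compound 2, with wide bounds on both sides: the estimate in this assay is 1800 nM, spanning 500 nM to 6500 nM, which amounts to an expected step of a 1.2-fold lower number from compound 2 to compound 3 (0.09 log units; within the scatter).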

Compound 3, half-maximal inhibitory concentration: 1900 nM
Estimate against measurement, compound 3: 1.1-fold (0.02 log units) below, and the stated range covers the measured number.
By their numbers in this assay, from the lowest: compound 1; then compounds 3 and 2 (each within the scatter of the next).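

In this assay, difluoromethyl and 2-hydroxyethyl on the saturated chain carbon bound to an aromatic carbon cannot be told apart, with a 1.2-fold lower number from compound 2 to compound 3 (0.06 log units; within the scatter), even though the entering group brings 1 hydrogen-bond donor and 1 hydrogen-bond acceptor and the leaving group brings neither. Compound 1 keeps the lowest number of the three, since a 3.2-fold higher number from compound 1 to compound 3 (0.50 log units; beyond the scatter) lies beyond the scatter, as does a 3.7-fold higher number from compound 1 to compound 2 (0.56 log units; beyond the scatter), so both changes from compound 1 lead to a higher number despite their different atoms. No accompanying data bear on the reason for this shared shift or for the lack of separation between compound 2 and compound 3.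

The compounds shown leave open whether a carboxylic acid or an amine in place of the hydroxyl of the 3-hydroxypropyl group, or a longer chain carrying the hydroxyl, would separate from compound 3 in either direction. They also leave open whether any group at this place can bring the number down to that of compound 1 or lower, as all the changes shown so far lead upward.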